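This account rests on a few compounds, and the source may have more. Where it says the series, first, only, none or still open, it means among the compounds named here.

Compound 3 `COc1ccc(/C=N\NC(=S)NC(C)(C)CCC[C@](C)(O)[C@@H]2CC=C(C)CC2)cc1` gives 34900 nM in a functional assay on K562 cells (Homo sapiens) for cytotoxicity, read by sulforhodamine B assay (a lower number here means a stronger inhibitor of growth, a higher number a weaker inhibitor of growth), the highest of the three numbers recorded. Compound 1 `CC1=CC[C@@H]([C@@](C)(O)CCCC(C)(C)NC(=S)NN)CC1` gives 380 nM in this assay, and compound 2 `CC1=CC[C@@H]([C@@](C)(O)CCCC(C)(C)NC(=S)N/N=C\c2ccccc2)CC1` gives 20900 nM there. The gap a 92-fold higher number from compound 1 to compound 3 (1.96 log units; beyond the scatter) lies beyond the scatter, whereas a 1.7-fold higher number from compound 2 to compound 3 (0.22 log units; within the scatter) lies within it. Compound 4 `CC1=CC[C@@H]([C@@](C)(O)CCCC(C)(C)NC(=S)N/N=C\c2ccccc2[N+](=O)[O-])CC1` is not yet measured; it differs from compound 3 by 2-nitrophenyl in place of 4-methoxyphenyl on a carbon with a double bond to nitrogen. For the measured compounds named here, the one measured step that bears on this change is a 1.7-fold higher number from compound 2 to compound 3 (0.22 log units; within the scatter), which stayed within the scatter, so exchanging the group on the aromatic ring has so far not moved the number. A step of similar size, within the scatter, is therefore expected in this assay for compound 4, namely a 1.2-fold lower number from compound 3 to compound 4 (0.07 log units; within the scatter). Compound 4 is estimated at 30000 nM in this assay, with a range of 12000 nM to 80000 nM.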

Compound 4, concentration for total growth inhibition: 7840 nM
Beside the measured number, compound 4's estimate is 3.8-fold (0.58 log units) above it; the measured number lies below the stated range.
By their numbers in this assay, from the lowest: compound 1; then compound 4; then compounds 2 and 3 (each within the scatter of the next).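

In this assay, exchanging the group on the carbon with a double bond to nitrogen proved able to move the number: a 4.5-fold lower number from compound 3 to compound 4 (0.65 log units; beyond the scatter) and a 2.7-fold lower number from compound 2 to compound 4 (0.43 log units; beyond the scatter) both lie beyond the scatter, unlike the earlier methoxy exchange. Among the three compounds with an aromatic ring, only nitro has so far lowered the number, yet compound 4 remains far above compound 1 at 380 nM. Still open is whether an amine or a carboxylic acid on the aromatic ring would lower the number further, and no evidence shown accounts for these steps.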